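This account rests on a few compounds, and the source may have more. Where it says the series, first, only, none or still open, it means among the compounds named here.

Measured so far:
- compound 1 `COc1cc(/C(Cl)=C/C=C(\C#N)C(=O)c2c[nH]c3ccc(Br)cc23)cc(OC)c1OC`: 50%
- compound 2 `N#C/C(=C\C=C(/Cl)c1ccc(Br)cc1)C(=O)c1c[nH]c2ccccc12`: 65.5%
- compound 3 `COc1ccc(/C(Cl)=C/C=C(\C#N)C(=O)c2c[nH]c3ccccc23)cc1`: 61.3%

In a functional assay for inhibition, with a stated time of 5 min, tested at 1 mM (on this read-out higher numbers stand for more inhibition at the one concentration tested (going by the name of the read-out) and lower numbers for less inhibition), compound 1 gives the lowest of the three numbers, while the values of compound 2 and compound 3 both lie higher by more than the usual scatter. Compound 2 and compound 3 differ in one place, (methoxy in place of bromo on an aromatic carbon), and this gave a number 4.2 percentage points lower from compound 2 to compound 3 (within the scatter). The difference between the core of compound 1 and the core of compound 2 is not broken down here.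

Compound 4 `COc1ccc2[nH]cc(C(=O)/C(C#N)=C/C=C(\Cl)c3cc(OC)c(OC)c(OC)c3)c2c1` has not yet been measured. It differs from compound 1 by methoxy in place of bromo on an aromatic carbon. Within the data shown here, this is the same kind of change as the one from compound 2 to compound 3, but not the same: there the ring was a six-membered aromatic ring of carbon only with the group para to a large group, whereas here the ring is part of a fused system of two rings, meta and para to a fused ring. Because the earlier change gave a number 4.2 percentage points lower from compound 2 to compound 3 (within the scatter), a small step is expected here as well, a number 2 percentage points lower from compound 1 to compound 4 (within the scatter). For compound 4 the estimate in this assay is 48%, expected to fall between 35% and 62%.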

Compound 4, a percentage reported as inhibition, at one concentration (the size of the read-out at that concentration, not a potency): 50%
Compound 4: middle estimate off by 2 percentage points, on the low side, within the range that was stated.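

In this assay, putting methoxy in place of bromo on the fused ring system gave no change at the digits printed from compound 1 to compound 4 (within the scatter). Set beside the earlier case, where the same swap was made on a ring of a different kind, the two steps agree as far as this read-out can tell: the same change on two cores in this assay, a number 4.2 percentage points lower (within the scatter) from compound 2 to compound 3 and no change at the digits printed (within the scatter) from compound 1 to compound 4, 4.2 percentage points apart, within the scatter of two such steps. Among these compounds, this suggests that, in these two pairs, the swap can be carried from one core to the other without a visible shift in the number, but it rests on only two pairs, both with steps inside the scatter, and it does not show that bromo and methoxy would be interchangeable on any further core.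

The compounds shown carry only bromo or methoxy at these places, so it stays open whether a very different group, such as an amine or a carboxylic acid, would move the number beyond the scatter. From the compounds shown here alone, each number is also a percentage at a single concentration rather than a potency, so how these compounds would compare across a range of concentrations stays open too.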